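The source may report more compounds than this note shows. Statements on the series, on what has been measured and on what is new or still open speak of the compounds shown alone.

Working notes on the series. Compound 1 `O=c1nc(NCc2cccc(F)c2)oc2c([N+](=O)[O-])cc(C(F)(F)F)cc12` is the reference point. In an ADME assay on Vero cells (Chlorocebus sabaeus) for cytotoxicity, read by MTT assay, with a stated time of 48 h (a lower number here means a stronger inhibitor, a higher number a weaker inhibitor), compound 1 gives only a limit, > 64 ug/mL, the reading sitting at the limit of > 64 ug/mL in this assay, at which 1 of the 2 values shown sits. Compound 2 `CC1CN(c2nc(=O)c3cc(C(F)(F)F)cc([N+](=O)[O-])c3o2)CCN1CC1CCCCC1`, which carries a different side arm on the shared core, gives 10.9 ug/mL in this assay. Compound 3 `CN(Cc1ccccc1)c1nc(=O)c2cc(C(F)(F)F)cc([N+](=O)[O-])c2o1` differs from compound 1 by benzyl(methyl)amino in place of (3-fluorobenzyl)amino on an aromatic carbon. Going by the values given here, no measured pair covers this change; in this assay a step no larger than the scatter, in either direction, is expected. Compound 3 is expected to give 70 ug/mL, within 30 ug/mL to 160 ug/mL. The expected step is a step that the limit leaves unreadable from compound 1 to compound 3, quite possibly again only a limit.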

Compound 3, half-maximal inhibitory concentration: 3.84 ug/mL
The estimate for compound 3 lay 18-fold (1.26 log units) above the measured number; the measured number lies below the stated range.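

In this assay, this aromatic carbon proves sensitive to the side arm: benzyl(methyl)amino in place of (3-fluorobenzyl)amino gives an at least 16-fold lower number from compound 1 to compound 3 (1.22 log units; beyond the scatter). The change keeps the heavy-atom count of the arm but removes its fluorine and its hydrogen-bond donor. Compound 1 stands at a limit, so the size of this step is only a bound: the limit of > 64 ug/mL in this assay, at which 1 of the 3 values shown sits.

The compounds shown do not separate the loss of fluorine from the added methyl on the amine. Plain benzylamino or (3-fluorobenzyl)(methyl)amino at this carbon would tell the two apart.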